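Acid series: chloro on the benzamide phenyl

The source may report more compounds than this note shows. Statements on the series, on what has been measured and on what is new or still open speak of the compounds shown alone.

Compound 3 `CN1CCN(c2ccc(Nc3nc(-c4cccc(NC(=O)c5ccccc5)c4)sc3C(=O)O)cc2)CC1` holds the lowest of the three numbers in a functional assay on Ramos cells (Homo sapiens) for antiproliferative activity, read by CCK-8 assay, with a stated time of 72 h, tested at 40 uM; a lower number here means less inhibition, a higher number more inhibition at the concentration tested (going by the name of the read-out): compound 3 gives 26.3%, whereas compound 1 `CCOC(=O)c1sc(-c2cccc(NC(=O)c3ccccc3)c2)nc1Nc1ccc(N2CCN(C)CC2)cc1` gives 77.1% and compound 2 `CCOC(=O)c1sc(-c2cccc(NC(=O)c3ccco3)c2)nc1Nc1ccc(N2CCN(C)CC2)cc1` gives 50.2%. The measured steps are a number 50.8 percentage points lower from compound 1 to compound 3 (beyond the scatter) and a number 26.9 percentage points lower from compound 1 to compound 2 (beyond the scatter). Compound 4 `CN1CCN(c2ccc(Nc3nc(-c4cccc(NC(=O)c5ccc(Cl)cc5)c4)sc3C(=O)O)cc2)CC1` differs from compound 3 by chloro in place of hydrogen on an aromatic carbon. Going by the values given here, of the two steps, only the one to compound 2, which also alters the group on the carbonyl carbon, touches the same part of the molecule; the ester-to-acid step does not bear on it. Among the compounds with values here, no measured step adds a chloro anywhere, so the change is expected to stay near the scatter. For compound 4 the expected step is a number 3.7 percentage points higher from compound 3 to compound 4 (within the scatter). Compound 4 is estimated at 30%, with a range from 10% to 55%.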

Compound 4, a percentage reported as inhibition, at one concentration (the size of the read-out at that concentration, not a potency): 71.6%
Compound 4: the middle estimate sits 41.6 percentage points below what was measured; the measured number lies above the stated range.
By their numbers in this assay, from the lowest: compound 3; then compound 2; then compounds 4 and 1 (each within the scatter of the next).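

Going by these compounds alone, putting 4-chlorophenyl in place of phenyl on the acid gives a number 45.3 percentage points higher from compound 3 to compound 4 (beyond the scatter) in this assay, so this aromatic ring responds strongly to one added chloro, whereas the only earlier change to the group on this carbonyl, in the ester pair, was a number 26.9 percentage points lower from compound 1 to compound 2 (beyond the scatter). The carboxylic acid therefore does not by itself hold the number low: compound 4 carries it and gives 71.6%. Nothing measured here accounts for the rise. On these data alone, whether fluoro, bromo or methoxy on this ring acts like chloro remains open, as does the effect of chloro on the ethyl ester.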